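This account rests on a few compounds, and the source may have more. Where it says the series, first, only, none or still open, it means among the compounds named here.

Compound 1 `CC(=O)SCCC(CCCCC(=O)O)SC(C)=O`: 8.03%
Compound 2 `O=C(O)CCCCC(CCSC(=O)c1ccccc1)SC(=O)c1ccccc1`: 89.8%
Compound 3 `O=C(CCCCC(S)CCS)Nc1cccc2ccccc12`: "not active" (no number reported)

These results come from a functional assay on KB cells (Homo sapiens) for inhibition, read by MTT assay, with a stated time of 24 h, tested at 100 ug/mL; on this read-out lower numbers stand for less inhibition of growth and higher numbers for more inhibition of growth at the one concentration tested. Of the two compounds with a number, compound 2 stands highest at 89.8%, and compound 1 gives 8.03%. The gap between these two is well beyond the scatter. Compound 3 has no number to compare.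

Compound 4 `O=C(CCCCC(CCSC(=O)c1ccccc1)SC(=O)c1ccccc1)Nc1ccccc1` is compound 2 with a single change: anilino in place of hydroxy on a carbonyl carbon. Put another way, the carboxy group becomes phenylcarbamoyl.

For the measured compounds named here, no measured pair shows this change alone, so the guidance is loose. Going by the values given here, the one measured compound without a carboxy group, compound 3, is reported as "not active" (no number reported), and this hints at a fall, though compound 3 also differs from compound 2 elsewhere. A sizeable downward move beyond the scatter is therefore expected, with an estimated step of a number 44.8 percentage points lower from compound 2 to compound 4 (beyond the scatter). The estimated value for compound 4 is 45%, with an expected range of 10% to 88%.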

Compound 4, percent growth inhibition at one concentration: "not active" (no number reported)
Nothing numeric was reported for compound 4, so the estimate cannot be set against anything.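

For the compounds shown here, compound 4, reported as "not active", carries no number, so no step from compound 2 to compound 4 can be read. Nothing measured here accounts for this result. The compounds shown leave open how much growth inhibition changes when carboxy becomes phenylcarbamoyl.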